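Quinolin-3-yl in place of quinolin-5-yl

The compounds below may be only part of what the source reports. "The series", "measured", "known", "first", "only" and "open" are said of these compounds alone.

- compound 1 `OC1CN(c2nccnc2OC2CN(c3ccc4ccccc4n3)C2)C1`: 41000 nM
- compound 2 `c1ccc2nc(N3CC(Oc4nccnc4-c4cccc5ncccc45)C3)ccc2c1`: 47000 nM

Both values come from a physicochemical assay for solubility, in phosphate buffer, at pH 7.4; on this read-out higher numbers stand for higher solubility and lower numbers for lower solubility. Among the measured compounds shown here, compound 2 at 47000 nM stands within the scatter of compound 1 at 41000 nM, the only other measured compound. The next compound is compound 3 `c1ccc2ncc(-c3nccnc3OC3CN(c4ccc5ccccc5n4)C3)cc2c1`, and the change is quinolin-3-yl in place of quinolin-5-yl on an aromatic carbon: the two have the same atoms, joined differently, with quinolin-3-yl in place of quinolin-5-yl on an aromatic carbon. For the measured compounds named here, the one measured step that bears on this is a 1.1-fold higher number from compound 1 to compound 2 (0.06 log units; within the scatter), which exchanged 3-hydroxyazetidin-1-yl for quinolin-5-yl. Going by the values given here, no measured step compares quinolin-3-yl with quinolin-5-yl, so the evidence is thin and the range is kept wide. No step beyond the scatter is expected in this assay, in either direction. The expected change is a 1.2-fold lower number from compound 2 to compound 3 (0.07 log units; within the scatter). The estimate for compound 3 is 40000 nM, with an expected range of 15000 nM to 90000 nM.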

Compound 3, solubility: < 1000 nM
Compound 3 ended at the assay's limit (the forecaster's own chance of this, stated with the estimate: 10%); middle value at least 40-fold (1.60 log units) from the limit.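

On the aromatic carbon next to the ring nitrogen, quinolin-3-yl in place of quinolin-5-yl, with the same atoms joined differently, gives an at least 47-fold lower number from compound 2 to compound 3 (1.67 log units; beyond the scatter) in this assay. Set against 3-hydroxyazetidin-1-yl, the same group gives an at least 41-fold lower number from compound 1 to compound 3 (1.61 log units; beyond the scatter), so at this position the point of attachment of the group carries a large effect that the earlier pair, within the scatter of each other, did not reveal. Compound 3 stands as a limit and not a number, so both steps give only a minimum size: the limit of < 1000 nM in this assay, at which 1 of the 3 values shown sits.

How far compound 3 lies past that limit stays open, and the compounds shown give no measured property that accounts for the drop. Also open, from the compounds shown here alone, is whether an amine or a carboxylic acid carried on quinolin-3-yl would bring the number back up to the level of compound 2.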